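The compounds below may be only part of what the source reports. "The series", "measured", "known", "first", "only" and "open" are said of these compounds alone.

Working notes on the stilbene series in a functional assay on HT-29 cells (Homo sapiens) for inhibition, read by MTT assay, with a stated time of 2 days; on this read-out lower numbers stand for stronger inhibition and higher numbers for weaker inhibition.

Of the compounds shown here, three have been measured. Compound 1 `Oc1ccc(/C=C/c2ccccc2O)cc1` gives 22 ug/mL in this assay. Compound 2 `COc1ccc(/C=C/c2ccccc2O)cc1` gives 10 ug/mL. Compound 3 `Nc1ccc(/C=C/c2ccccc2O)cc1` gives 37 ug/mL, which is the highest of the three numbers; the recorded step a 1.7-fold higher number from compound 1 to compound 3 (0.23 log units; within the scatter) lies within the scatter, so those two values are not separated, while the recorded step a 3.7-fold higher number from compound 2 to compound 3 (0.57 log units; beyond the scatter) lies beyond it.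

Compound 4 `COc1ccccc1/C=C/c1ccc(N)cc1` is the next to be measured. It differs from compound 3 by methyl in place of hydrogen on an oxygen on an aromatic ring. Going by the values given here, the one recorded step of the same kind is a 2.2-fold lower number from compound 1 to compound 2 (0.34 log units; beyond the scatter), a modest shift beyond the scatter toward a lower number. On that basis the step from compound 3 to compound 4 in this assay is expected to be of similar size and direction, a 2.2-fold lower number from compound 3 to compound 4 (0.34 log units; beyond the scatter). Compound 4 is therefore estimated at 17 ug/mL, with a range from 8 ug/mL to 35 ug/mL.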

Compound 4, half-maximal inhibitory concentration: 22 ug/mL
Estimate against measurement, compound 4: 1.3-fold (0.11 log units) below; measured number inside the range.
By their numbers in this assay, from the lowest: compound 2; then compounds 1, 4 and 3 (each within the scatter of the next).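

In this assay, methyl in place of hydrogen on an oxygen on an aromatic ring now appears on a second core and at a different oxygen, and here the step is a 1.7-fold lower number from compound 3 to compound 4 (0.23 log units; within the scatter). Hydroxy to methoxy therefore does not separate this pair, whereas the earlier example, a 2.2-fold lower number from compound 1 to compound 2 (0.34 log units; beyond the scatter), lay beyond the scatter. Even so, the two steps cannot be told apart, so the data show no difference in this change between the two cores: the same change on two cores in this assay, a 2.2-fold lower number (0.34 log units; beyond the scatter) from compound 1 to compound 2 and a 1.7-fold lower number (0.23 log units; within the scatter) from compound 3 to compound 4, 1.3-fold (0.12 log units) apart, within the scatter of two such steps.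

The compounds shown leave open what an ethyl group or a longer chain on this oxygen would do, since methyl is the only group placed there. They also leave open whether a carboxylic acid in place of the hydroxy at this position would shift the number beyond the scatter.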